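Adding trifluoromethyl to compound 3

A few compounds are considered here, and "the series" means these few. Any claim that something is new, unique, unknown or untested is made for them only; others in the source may bear on it.

Measured so far:
Compound 1 (`CN(c1ccccc1)c1cc(C(=O)Nc2ccccc2)ncn1`) gives < 5000 nM (a limit)
Compound 2 (`CN(Cc1ccc(Cl)cc1)c1cc(C(=O)Nc2ccccc2)ncn1`) gives < 5000 nM (a limit)
Compound 3 (`CN(Cc1cccnc1)c1cc(C(=O)Nc2ccccc2)ncn1`) gives 150000 nM (a number)

Going by the values given here, in a physicochemical assay for solubility, using the shake flask method, measured as kinetic solubility, with a stated time of 2 h, at pH 7.4 (on this read-out higher numbers stand for higher solubility and lower numbers for lower solubility), compound 3 gives 150000 nM as the only true number. The other two compounds sit at the limit of < 5000 nM in this assay, at which 2 of the 3 values shown sit, and cannot be ranked against each other.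

The change to compound 4 (`CN(Cc1ccc(C(F)(F)F)nc1)c1cc(C(=O)Nc2ccccc2)ncn1`) is trifluoromethyl in place of hydrogen on an aromatic carbon.

Among the compounds with values here, two measured steps bear on this. Replacing phenyl with (pyridin-3-yl)methyl on the nitrogen gave an at least 30-fold higher number from compound 1 to compound 3 (1.47 log units; beyond the scatter) as a large result. Replacing 4-chlorophenyl with pyridin-3-yl gave an at least 30-fold higher number from compound 2 to compound 3 (1.47 log units; beyond the scatter) as a second large result. Compound 4 keeps the ring nitrogen of compound 3 but, like compound 2, carries a substituent on that ring. A clear fall in this assay is therefore expected, though one that may stop short of the limit seen for compound 2. The expected change is a 10-fold lower number from compound 3 to compound 4 (1.00 log units; beyond the scatter) on this estimate. For compound 4 the estimate is 15000 nM with an expected range of 5000 nM to 60000 nM in this read-out.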

Compound 4, solubility: < 5000 nM
Compound 4 ended at the assay's limit; the forecaster's own chance of this, stated with the estimate: 25%; at least 3.0-fold (0.47 log units) between middle value and limit.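

Trifluoromethyl on an aromatic carbon next to the ring nitrogen, para to a large group, gives an at least 30-fold lower number from compound 3 to compound 4 (1.47 log units; beyond the scatter) in this assay. Going by these compounds alone, the earlier steps tied the one measured number to the pyridin-3-yl group, and compound 4 now shows that keeping the ring nitrogen is not enough on its own to keep the read-out off the limit, since this one substitution on that ring is sufficient to reach it. The value of compound 4 is a limit, and compound 4 cannot be ranked against compound 1 or compound 2: the limit of < 5000 nM in this assay, at which 3 of the 4 values shown sit.

On these data alone, whether methyl, methoxy or an amine on this same carbon would leave a readable number stays open. As far as these compounds go, it is also open whether trifluoromethyl on another carbon of the ring would give the same step.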